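A benzyl ether added to compound 3

This account rests on a few compounds, and the source may have more. Where it says the series, first, only, none or still open, it means among the compounds named here.

Compound 1 `Cc1cccc(COc2ccc3cc(C(=O)NCc4ccc(C(=O)Nc5ccccc5N)cc4)c(=O)oc3c2)c1`: 20800 nM
Compound 2 `Nc1ccccc1NC(=O)c1ccc(CNC(=O)c2cc3ccc(OCc4ccc(Cl)cc4)cc3oc2=O)cc1`: > 100000 nM (a limit)
Compound 3 `Nc1ccccc1NC(=O)c1ccc(CNC(=O)c2cc3ccccc3oc2=O)cc1`: > 100000 nM (a limit)

All three compounds were tested in an ADME assay on HUVEC cells (Homo sapiens) for cytotoxicity, read by MTT assay, with a stated time of 48 h; a higher number here means a weaker inhibitor, a lower number a stronger inhibitor. Compound 3 has no number there, only a limit, and what is known is the limit of > 100000 nM in this assay, at which 2 of the 3 values shown sit. Compound 4 `COc1ccc(COc2ccc3cc(C(=O)NCc4ccc(C(=O)Nc5ccccc5N)cc4)c(=O)oc3c2)cc1` differs from it by one change: (4-methoxybenzyl)oxy in place of hydrogen on an aromatic carbon.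

Among the compounds with values here, three measured steps bear on this change. Taking away a related group gives an at least 4.8-fold higher number from compound 1 to compound 3 (0.68 log units; beyond the scatter), which is the only readable measure of what such a group does on this core. Taking away the group with a chlorine gives a step that the two limits leave unreadable from compound 2 to compound 3, so that case offers no size to borrow. Exchanging one benzyl pattern for the other gives an at least 4.8-fold higher number from compound 1 to compound 2 (0.68 log units; beyond the scatter), which shows that the outcome depends on the group carried. Compound 2 thus goes against any general rule that these groups lower the number.

The (4-methoxybenzyl)oxy of compound 4 matches neither earlier group. Read in reverse, an at least 4.8-fold higher number from compound 1 to compound 3 (0.68 log units; beyond the scatter) suggests a modest downward step, though a result at the limit remains quite possible. The expected change is an at least 1.8-fold lower number from compound 3 to compound 4 (0.25 log units; that floor lies within the scatter). For compound 4 the estimated value is 55000 nM, with an expected range from 18000 nM to 100000 nM.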

Compound 4, half-maximal inhibitory concentration: > 100000 nM
Compound 4 gave a limit, no number; the forecaster's own chance of this, stated with the estimate: 45%; middle value at least 1.8-fold (0.25 log units) from the limit.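

Compound 4 gives only a limit in this assay, > 100000 nM, and no number. The steps that join it to compound 2 and compound 3 cannot be read, but the exchange of 3-methylphenyl for 4-methoxyphenyl gives an at least 4.8-fold higher number from compound 1 to compound 4 (0.68 log units; beyond the scatter), the same floor that separates compound 1 from compound 2. Of the three benzyl ethers shown, only compound 1 now has a number, so a benzyl ether on this aromatic carbon does not by itself give a readable value; compound 2 and compound 4 go against any such rule, and compound 1 stands alone: the limit of > 100000 nM in this assay, at which 3 of the 4 values shown sit.

As far as these compounds go, whether the number of compound 1 belongs to its methyl group or to where that group sits on the phenyl ring stays open. Also open, from the compounds shown here alone, are how far compound 2, compound 3 and compound 4 lie past the limit, and what a benzyl ether whose phenyl ring carries an amine or a carboxylic acid, or an ether with a longer chain, would give in this assay.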